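Cytotoxicity of Methoxy and Isopropoxy Analogues in Rat Cells

A few compounds are considered here, and "the series" means these few. Any claim that something is new, unique, unknown or untested is made for them only; others in the source may bear on it.

Four closely related compounds were examined for their effect on cultured rat cells. Compound 1 `COc1cccc(C(O)(c2ccc(Cl)cc2)c2cccnc2)c1` carries a methoxy group, and compound 3 `CC(C)Oc1cccc(C(O)(c2ccc(Cl)cc2)c2cccnc2)c1` differs from it in one place: isopropyl in place of methyl on an oxygen on an aromatic ring. Compound 2 `COc1ccc(C(O)(c2ccc(Cl)cc2)c2cccnc2)cc1` is built from the same atoms as compound 1, joined differently, and the difference between the two cores is not broken down here. Compound 4 `CC(C)Oc1ccc(C(O)(c2ccc(Cl)cc2)c2cccnc2)cc1` stands to compound 2 as compound 3 stands to compound 1: isopropyl in place of methyl on an oxygen on an aromatic ring. The two place descriptions read word for word alike, so this is the same change made on two cores.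

In an ADME assay on L6 cells (Rattus norvegicus) for cytotoxicity, read by resazurin assay, with a stated time of 72 h (a lower number here means a stronger inhibitor, a higher number a weaker inhibitor), compound 1 gives 85600 nM, compound 2 gives 68100 nM, and compound 3 gives 67600 nM. All three numbers lie within the scatter of one another, so no order among them can be claimed. Among the compounds with values here, the one change that has already been measured, a 1.3-fold lower number from compound 1 to compound 3 (0.10 log units; within the scatter), did not move the number beyond the scatter.

Compound 4 has not yet been measured in this assay. The step from compound 2 to compound 4 is expected to be small, a 1.2-fold lower number from compound 2 to compound 4 (0.07 log units; within the scatter), since the matching step a 1.3-fold lower number from compound 1 to compound 3 (0.10 log units; within the scatter) stayed within the scatter. Compound 4 is therefore estimated at 58000 nM, with a likely range from 30000 nM to 115000 nM.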

Compound 4, half-maximal inhibitory concentration: 56600 nM
Compound 4: middle estimate off by 1.0-fold (0.01 log units), on the high side, within the range that was stated.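

In this assay, exchanging methoxy for isopropoxy on the second core gives a 1.2-fold lower number from compound 2 to compound 4 (0.08 log units; within the scatter), so this replacement of a methyl by an isopropyl on the oxygen leaves no readable mark on the number. Set beside the same change on the first core, the new step tells the same story, and the two steps cannot be told apart: the same change on two cores in this assay, a 1.3-fold lower number (0.10 log units; within the scatter) from compound 1 to compound 3 and a 1.2-fold lower number (0.08 log units; within the scatter) from compound 2 to compound 4, 1.1-fold (0.02 log units) apart, within the scatter of two such steps What this supports is a modest statement: on these two cores, the change stayed within the scatter both times, so a chemist could make this swap on either core and expect the number to hold, but two cores cannot show that the same would happen on a third, and steps this small cannot show whether the change has any real effect at all.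

The compounds shown span only methyl and isopropyl on that oxygen, so they leave open whether anything placed there could shift the number beyond the scatter in this assay. A longer chain such as n-butyl, or a chain ending in an amine or a carboxylic acid, would test the question more severely than this small step does.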